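Pyridin-2-yl in Place of Phenyl on the Amide

A few compounds are considered here, and "the series" means these few. Any claim that something is new, unique, unknown or untested is made for them only; others in the source may bear on it.

Compound 1 `O=C(Nc1ccccc1)c1cccc2oc(=O)[nH]c12` gives 2200 nM in an assay on isolated protein for binding affinity to metabotropic glutamate receptor 5 (Homo sapiens); on this read-out higher numbers stand for weaker inhibition and lower numbers for stronger inhibition.
Compound 2 `O=C(Nc1ccccc1Cl)c1cccc2oc(=O)[nH]c12` gives > 10000 nM in this assay, and this value is a limit of the assay rather than a number.
Compound 3 `O=C(Nc1ccc(Cl)cc1)c1cccc2oc(=O)[nH]c12` gives 3800 nM in this assay.

Among the two numbers shown, compound 1 has the lowest, and compound 3 sits nearest to it: a 1.7-fold higher number from compound 1 to compound 3 (0.24 log units; within the scatter), a difference that lies within the usual scatter. The other measured step, an at least 4.5-fold higher number from compound 1 to compound 2 (0.65 log units; beyond the scatter), reaches the limit of the assay at which compound 2 sits (the limit of > 10000 nM in this assay, at which 1 of the 3 values shown sits).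

Compound 4 `O=C(Nc1ccccn1)c1cccc2oc(=O)[nH]c12` differs from compound 1 in one place: pyridin-2-yl in place of phenyl on an amide-type nitrogen. Neither measured step bears directly on this change, since both of them concern chloro in place of hydrogen on an aromatic carbon, not a replacement of the whole ring on the amide-type nitrogen. Going by the values given here, the shared core and the amide are untouched, so the starting point remains compound 1 and no large step in this assay is expected in either direction. Compound 4 is therefore estimated at 3000 nM, with a range from 1000 nM to 10000 nM, and the expected step is a 1.4-fold higher number from compound 1 to compound 4 (0.13 log units; within the scatter).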

Compound 4, inhibition constant: 251 nM
The estimate for compound 4 lay 12-fold (1.08 log units) above the measured number; measured number below the stated range.
By their numbers in this assay, from the lowest: compound 4; then compounds 1 and 3 (each within the scatter of the next). At a limit, above all of these: compound 2.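

In this assay the ring on the amide-type nitrogen proves able to move the number downward, with an 8.8-fold lower number from compound 1 to compound 4 (0.94 log units; beyond the scatter) on going from phenyl to pyridin-2-yl. Of the three single changes to compound 1 shown here, this is the only one that gives a lower number beyond the usual scatter, whereas the two chloro replacements do not. The swap leaves the number of heavy atoms in the ring unchanged, exchanging one ring carbon for a nitrogen and adding a hydrogen-bond acceptor, so a large shift here does not require a larger group.

Nothing shown here establishes why this exchange gives the lower number, and the count of acceptors is a description of the change rather than a demonstrated cause. On these data alone, it remains open whether pyridin-3-yl or pyridin-4-yl, which carry the ring nitrogen elsewhere, would match compound 4, and whether pyrimidin-2-yl, or a methyl or chloro group on the pyridin-2-yl ring, would lower the number further or lose the effect.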